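Cytotoxicity limits in a thiopyranopyrimidine amide series

The compounds below may be only part of what the source reports. "The series", "measured", "known", "first", "only" and "open" are said of these compounds alone.

Three compounds have been run in an ADME assay on L02 cells (Homo sapiens) for cytotoxicity, read by MTT assay, with a stated time of 72 h (a lower number here means a stronger inhibitor, a higher number a weaker inhibitor), and every value is a limit of the assay rather than a number:
compound 1 `CC/C=C/C(=O)Nc1cccc(Oc2nc(Nc3ccn(C)n3)nc3c2CSCC3)c1` gives > 50000 nM.
compound 2 `CC(C)/C=C/C(=O)Nc1cccc(Oc2nc(Nc3ccn(C)n3)nc3c2CSCC3)c1` gives > 50000 nM.
compound 3 `CC/C=C/C(=O)Nc1cccc(Oc2nc(Nc3ccc(OC)nc3)nc3c2CSCC3)c1` gives > 50000 nM.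

Compound 2 differs from compound 1 by methyl in place of hydrogen on a saturated chain carbon bound to a double-bonded chain carbon and a saturated chain carbon; the step that the two limits leave unreadable from compound 1 to compound 2 cannot be read, since both values rest on (the limit of > 50000 nM in this assay, at which 3 of the 3 values shown sit). The cores of compound 1 and compound 3 differ by 6-methoxypyridin-3-yl in place of 1-methyl-1H-pyrazol-3-yl on a nitrogen on an aromatic ring, and here too the step that the two limits leave unreadable from compound 1 to compound 3 is unreadable for the same reason.

Compound 4 `CCC/C=C/C(=O)Nc1cccc(Oc2nc(Nc3ccc(OC)nc3)nc3c2CSCC3)c1` is not yet measured. It differs from compound 3 by methyl in place of hydrogen on a saturated chain carbon, two bonds along the chain from a double-bonded chain carbon. This is the same kind of change as from compound 1 to compound 2, not the same: there the methyl enters on a saturated chain carbon bound to a double-bonded chain carbon and a saturated chain carbon, here on a saturated chain carbon two bonds along the chain from a double-bonded chain carbon.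

The step from compound 3 to compound 4 is expected to be a step that the limit leaves unreadable from compound 3 to compound 4, resting on (the limit of > 50000 nM in this assay, at which 3 of the 3 values shown sit), where all three measured compounds sit. Compound 4 is thus expected at 80000 nM, most likely reported again as a limit, within 30000 nM to 300000 nM.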

Compound 4, half-maximal inhibitory concentration: > 50000 nM
Compound 4: a limit, no number; the forecaster's own chance of this, stated with the estimate: 85%; the middle value is on the limit's open side.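

In this assay compound 4 gives > 50000 nM, a limit and not a number. No step can be read from compound 3 to compound 4, as both values rest on the same limit: the limit of > 50000 nM in this assay, at which 4 of the 4 values shown sit.

The compounds shown leave open how far any of the four lies from that limit, and whether changing the chain or the aromatic group on the nitrogen alters the value at all.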